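From Cyclohexyl to Propyl on an Amide-Type Nitrogen

The compounds below may be only part of what the source reports. "The series", "measured", "known", "first", "only" and "open" are said of these compounds alone.

Compound 1 `Cc1ccc(NC(=O)Nc2ccc3c(c2)COC3=O)cc1`: 2670 nM
Compound 2 `O=C(Nc1ccc(F)cc1)Nc1ccc2c(c1)COC2=O`: 4190 nM
Compound 3 `O=C(Nc1ccc2c(c1)COC2=O)NC1CCCCC1`: 12700 nM

These three compounds share one core and differ only in the group on an amide-type nitrogen. In a functional assay on cells (T-cell, Mus musculus) for inhibition (on this read-out higher numbers stand for weaker inhibition and lower numbers for stronger inhibition), compound 3 stands highest of the three numbers. Its nearest neighbour is compound 2, with a 3.0-fold higher number from compound 2 to compound 3 (0.48 log units; beyond the scatter); its furthest is compound 1, with a 4.8-fold higher number from compound 1 to compound 3 (0.68 log units; beyond the scatter). The two aromatic groups sit close together, as a 1.6-fold higher number from compound 1 to compound 2 (0.20 log units; within the scatter) shows.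

Compound 4 `CCCNC(=O)Nc1ccc2c(c1)COC2=O` is the next compound. It differs from compound 3 in one place: propyl in place of cyclohexyl on an amide-type nitrogen. Among the measured compounds shown here, no measured step exchanges one non-aromatic group for another, so the only steps that bear on it are the two leading to compound 3, both modest and both toward weaker inhibition. Whether the propyl group continues that direction or sits within the scatter of compound 3 cannot be read from the data shown.

Compound 4 is therefore expected to give about 20000 nM in this assay, with a range from 6000 nM to 60000 nM. That estimate means a step of a 1.6-fold higher number from compound 3 to compound 4 (0.20 log units; within the scatter), expected to be at most modest.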

Compound 4, half-maximal inhibitory concentration: 58100 nM
For compound 4 the middle estimate is 2.9-fold (0.46 log units) below the measured one; measured number inside the range.
By their numbers in this assay, from the lowest: compounds 1 and 2 (each within the scatter of the next); then compound 3; then compound 4.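

In this assay, the exchange of one non-aromatic group for another on this amide-type nitrogen is not neutral: the change shows a 4.6-fold higher number from compound 3 to compound 4 (0.66 log units; beyond the scatter) and extends the direction of the steps that led to compound 3. The propyl group stands much further from the aromatic groups, with a 14-fold higher number from compound 2 to compound 4 (1.14 log units; beyond the scatter) and a 22-fold higher number from compound 1 to compound 4 (1.34 log units; beyond the scatter) as large steps, so that the aromatic groups, cyclohexyl and propyl fall in that order among these four compounds, with none going against it. No evidence is available to explain this order.

On these data alone, it remains open whether a longer chain such as hexyl, or a smaller ring such as cyclopentyl, would fit this order. As far as these compounds go, the effect of an amine or a carboxylic acid carried on the propyl chain also remains open.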